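Chloro position on the phenylthio methyl side chain

A few compounds are considered here, and "the series" means these few. Any claim that something is new, unique, unknown or untested is made for them only; others in the source may bear on it.

Measured so far in an assay on isolated protein for binding affinity to Equilibrative nucleoside transporter 1 (Homo sapiens); a lower number here means a stronger inhibitor, a higher number a weaker inhibitor:
compound 1 `OC[C@H]1O[C@@H](n2cnc3c(OCc4ccccc4)ncnc32)[C@H](O)[C@@H]1O`: 2090 nM
compound 2 `OC[C@H]1O[C@@H](n2cnc3c(CSc4ccccc4Cl)ncnc32)[C@H](O)[C@@H]1O`: 1780 nM

Compound 2 gives the lowest of the two numbers, but its neighbour compound 1 sits within the scatter, so no order between them can be read. Within the data shown here, the only step so far, a 1.2-fold lower number from compound 1 to compound 2 (0.07 log units; within the scatter), exchanged the whole side chain and stayed within the scatter.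

Compound 3 `OC[C@H]1O[C@@H](n2cnc3c(CSc4cccc(Cl)c4)ncnc32)[C@H](O)[C@@H]1O` differs from compound 2 only in the position of the chlorine: 3-chlorophenyl in place of 2-chlorophenyl on a sulfur. Among the measured compounds shown here, no measured step concerns a shift of a substituent around the phenyl ring, so nothing bears directly on this change; the one step known, from benzyloxy to the chlorophenylthio methyl chain, was itself flat.

Hence no step beyond the scatter is expected, and compound 3 is estimated at 1800 nM (range 600 nM to 5400 nM), a step of a 1.0-fold higher number from compound 2 to compound 3 (0.00 log units; within the scatter) in this assay.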

Compound 3, half-maximal inhibitory concentration: 282 nM
Compound 3: the middle estimate sits 6.4-fold (0.81 log units) above what was measured, outside the stated range (below it).
By their numbers in this assay, from the lowest: compound 3; then compounds 2 and 1 (each within the scatter of the next).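

Among these compounds, with the same atoms joined differently, the place of the chlorine on the phenyl ring attached to sulfur matters in this assay: 3-chlorophenyl in place of 2-chlorophenyl gives a 6.3-fold lower number from compound 2 to compound 3 (0.80 log units; beyond the scatter), the first step beyond the scatter. The change from benzyloxy to the chlorophenylthio methyl side chain, flat with 2-chlorophenyl, is no longer flat with 3-chlorophenyl, giving a 7.4-fold lower number from compound 1 to compound 3 (0.87 log units; beyond the scatter). Nothing measured on these compounds accounts for the difference between the two chlorine positions.

Open, on these data alone, is whether this result belongs to chlorine itself or would also hold for a methoxy group or a nitrile in its place. Also open, as far as these compounds go, is whether an unsubstituted phenyl on the sulfur would stand nearer compound 2 or compound 3.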